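The compounds below may be only part of what the source reports. "The series", "measured", "known", "first", "only" and "open" are said of these compounds alone.

Compound 2 `c1cncc(-c2nnc(-c3c[nH]c4ccccc34)o2)c1` gives 711000 nM in a functional assay on PC-3 cells (Homo sapiens) for cytotoxicity, read by MTT assay (on this read-out lower numbers stand for stronger inhibition and higher numbers for weaker inhibition), the highest of the two numbers seen. Compound 1 `c1ccc2c(-c3nnc(-c4ccncc4)o3)c[nH]c2c1` gives 4100 nM, and the change from compound 1 to compound 2 brought a 170-fold higher number from compound 1 to compound 2 (2.24 log units; beyond the scatter). Compound 3 `COc1ccc(-c2nnc(-c3c[nH]c4ccccc34)o2)cc1OC` gives > 1000000 nM, which is the limit of > 1000000 nM in this assay, at which 1 of the 3 values shown sits, and not a number. Compound 4 `FC(F)(F)c1nnc(-c2c[nH]c3ccccc23)o1` carries trifluoromethyl in place of pyridin-3-yl on an aromatic carbon. Within the data shown here, no measured step exchanges pyridin-3-yl for trifluoromethyl, so the single step seen, the large one from compound 1 to compound 2, does not bear on it directly, and no step beyond the scatter can be expected in either direction, though the uncertainty is wide. Compound 4 is therefore estimated at 500000 nM, within 70000 nM to 3000000 nM, which would mean a 1.4-fold lower number from compound 2 to compound 4 (0.15 log units; within the scatter).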

Compound 4, half-maximal inhibitory concentration: > 1000000 nM
Compound 4: a limit, no number; the forecaster's own chance of this, stated with the estimate: 40%; at least 2.0-fold (0.30 log units) between middle value and limit.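

Compound 4 gives a limit, not a number, in this assay: the limit of > 1000000 nM in this assay, at which 2 of the 4 values shown sit. Trifluoromethyl in place of pyridin-3-yl brings an at least 1.4-fold higher number from compound 2 to compound 4 (0.14 log units; that floor lies within the scatter), so this floor cannot rank the two groups. Trifluoromethyl in place of pyridin-4-yl brings an at least 240-fold higher number from compound 1 to compound 4 (2.38 log units; beyond the scatter), which shows that a group with no ring on this carbon also falls far short of pyridin-4-yl. Going by these compounds, how far past its limit compound 4 truly lies remains open. So does whether an amine or a carboxylic acid on this carbon would come closer to compound 1.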